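Swapping bromo for iodo at one ring carbon

This account rests on a few compounds, and the source may have more. Where it says the series, first, only, none or still open, it means among the compounds named here.

Measured so far:
compound 1 `Cn1c(-c2ccccc2)cc(=O)[nH]c1=O` gives 27%
compound 2 `Cn1c(N)nc(-c2ccccc2)c(I)c1=O` gives 18%
compound 3 `Cn1c(-c2ccccc2)c(Br)c(=O)[nH]c1=O` gives 22%

All three were tested in a functional assay on the whole organism for inhibition, with Rattus norvegicus as the target, at a dose of 25 mg/kg by the oral route; a higher number here means a stronger effect of the compound at the dose given, a lower number a weaker effect. Compound 3 `Cn1c(-c2ccccc2)c(Br)c(=O)[nH]c1=O` stands second of the three numbers, with compound 2 near it at a number a few points lower and compound 1 a few points higher, both gaps within the scatter, so no order among the three can be read from these numbers.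

Compound 4 `Cn1c(-c2ccccc2)c(I)c(=O)[nH]c1=O` is the compound not yet measured. It differs from compound 3 by iodo in place of bromo on an aromatic carbon.

Going by the values given here, one measured step touches the same place: a number 5 percentage points lower from compound 1 to compound 3 (within the scatter). That step put bromo where hydrogen had been and stayed within the scatter. Among the compounds with values here, no measured pair swaps one halogen for another, so the data give no direct guide to the bromo-to-iodo exchange. Given that filling this position with bromo changed little, the expectation is a step of about no change at the digits printed from compound 3 to compound 4 (within the scatter), that is, nothing beyond the scatter. Compound 4 is therefore estimated at 22%, with a range from 8% to 36%.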

Compound 4, a percentage reported as inhibition, in the whole organism at one dose (the size of the read-out at that dose, not a potency): 33%
Compound 4: the middle estimate sits 11 percentage points below what was measured; low and high end bracket the measured number.
By their numbers in this assay, from the lowest: compounds 2, 3, 1 and 4 (each within the scatter of the next, the first and the last beyond it).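

In this assay this ring carbon no longer looks indifferent to what it carries: exchanging one halogen for the other gives a number 11 percentage points higher from compound 3 to compound 4 (beyond the scatter). Neither halogen stands clearly apart from hydrogen, though, since iodo in place of hydrogen gives a number 6 percentage points higher from compound 1 to compound 4 (within the scatter), so the clear difference here lies between bromo and iodo and not between a halogen and no halogen. Nothing available here explains the gap between the two halogens.

The compounds shown leave open what chloro, fluoro, a methyl group or an amine would do at this carbon, and so whether the halogens follow any trend at all. Each compound also appears at a single dose, which leaves open how the effect would change at other doses.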